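Chloro in place of nitro: notes on compound 3

This account rests on a few compounds, and the source may have more. Where it says the series, first, only, none or still open, it means among the compounds named here.

Of the compounds shown here, two with a shared core have been read so far in a functional assay on SW-620 cells (Homo sapiens) for antiproliferative activity, read by MTT assay, with a stated time of 24 h; a lower number here means a stronger inhibitor, a higher number a weaker inhibitor. There, compound 1 (`COc1ccc(C(=O)/C=C/c2ccc(-c3ccccc3)cc2)c2c1C=CC(C)(C)O2`) gives > 10000 nM and this is a limit of the assay, not a number. Among the compounds with values here, compound 2 (`COc1ccc(C(=O)/C=C/c2cccc([N+](=O)[O-])c2)c2c1C=CC(C)(C)O2`) gives 4090 nM as the only actual number, so it has no measured neighbour to be ranked against. Compound 3 (`COc1ccc(C(=O)/C=C/c2cccc(Cl)c2)c2c1C=CC(C)(C)O2`) carries chloro in place of nitro on an aromatic carbon, meta to a large group (chloro in place of nitro on an aromatic carbon), the change from 3-nitrophenyl to 3-chlorophenyl. Within the data shown here, no measured step covers this swap, so the expectation rests on compound 2 alone (4090 nM). The expected change (a 1.2-fold higher number from compound 2 to compound 3 (0.09 log units; within the scatter)) stays within the usual scatter, with no firm direction. The estimate for compound 3 is 5000 nM (expected range 1800 nM to 10000 nM).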

Compound 3, half-maximal inhibitory concentration: > 10000 nM
Compound 3 ended at the assay's limit; the forecaster's own chance of this, stated with the estimate: 20%; at least 2.0-fold (0.30 log units) between middle value and limit.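

In this assay, within the data shown here, the aromatic carbon carrying nitro is not indifferent to this swap: replacing nitro with chloro gives an at least 2.4-fold higher number from compound 2 to compound 3 (0.38 log units; beyond the scatter), the first measured step. Compound 3 gives > 10000 nM, which is a limit of the assay and not a number. The step therefore fixes only a minimum size, because the reading for compound 3 stops at a limit: the limit of > 10000 nM in this assay, at which 2 of the 3 values shown sit.

Among these compounds, with only one actual number, it remains open whether another group at this place, such as an amine or a carboxylic acid, would give a lower number than nitro in this assay. Compound 1 and compound 3 both stand at a limit and cannot be ranked against each other.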